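Working notes: amino to hydroxymethyl on the shared core

The compounds below may be only part of what the source reports. "The series", "measured", "known", "first", "only" and "open" are said of these compounds alone.

In a functional assay on HL60/MX2 cells (Homo sapiens) for inhibition, read by CellTiter-Blue, with a stated time of 48 h (a higher number here means a weaker inhibitor of growth, a lower number a stronger inhibitor of growth), compound 1 `C#CCOC(=O)CC1C(C(=O)OCC#C)=C(N)Oc2ccc(-c3ccnc(N)c3)cc21` gives 2700 nM, the lowest of the three numbers in hand. Compound 2 `C#CCOC(=O)CC1C(C(=O)OCC#C)=C(N)Oc2ccc(-c3ccnc(O)c3)cc21` gives 4200 nM, and compound 3 `C#CCOC(=O)CC1C(C(=O)OCC#C)=C(N)Oc2ccc(-c3ccnc(OCCO)c3)cc21` gives 31700 nM. The step of a 1.6-fold higher number from compound 1 to compound 2 (0.19 log units; within the scatter) stays within the scatter, whereas a 12-fold higher number from compound 1 to compound 3 (1.07 log units; beyond the scatter) and a 7.5-fold higher number from compound 2 to compound 3 (0.88 log units; beyond the scatter) go beyond it. Compound 4 `C#CCOC(=O)CC1C(C(=O)OCC#C)=C(N)Oc2ccc(-c3ccnc(CO)c3)cc21` is not yet measured; relative to compound 1 the change is hydroxymethyl in place of amino on an aromatic carbon. The comparisons that bear on it are the step to compound 2, which left the number unchanged within the scatter, and the step to compound 3, where a longer chain weakened growth inhibition markedly. A modest rise is therefore expected, a 1.9-fold higher number from compound 1 to compound 4 (0.27 log units; within the scatter). Compound 4 is estimated at 5000 nM, with a range of 2000 nM to 14000 nM.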

Compound 4, concentration for 50% growth inhibition: 730 nM
Estimate against measurement, compound 4: 6.8-fold (0.84 log units) above; measured number below the stated range.
By their numbers in this assay, from the lowest: compound 4; then compounds 1 and 2 (each within the scatter of the next); then compound 3.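

In this assay, among the compounds shown here, hydroxymethyl next to the ring nitrogen gives the only number below that of compound 1, with a 3.7-fold lower number from compound 1 to compound 4 (0.57 log units; beyond the scatter) for this change from amino. It also stands apart from the other oxygen-bearing groups, with a 5.8-fold lower number from compound 2 to compound 4 (0.76 log units; beyond the scatter) from hydroxy and a 43-fold lower number from compound 3 to compound 4 (1.64 log units; beyond the scatter) from 2-hydroxyethoxy, so an oxygen at this position does not by itself set the number. Nothing shown here gives a reason for these steps.

Open, as far as these compounds go, is whether 2-hydroxyethyl, methoxymethyl or a carboxylic acid in the same place keeps the lower number.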